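Shortening the phosphate chain of uracil nucleotides

The compounds below may be only part of what the source reports. "The series", "measured", "known", "first", "only" and "open" are said of these compounds alone.

Compound 1 `Cc1cc(=O)n([C@@H]2O[C@H](COP(=O)(O)OP(=O)(O)OP(=O)(O)O)[C@@H](O)[C@H]2O)c(=O)[nH]1`: in an in vitro functional assay on 1321-N1 cells for agonist activity at P2Y purinoceptor 2 (Homo sapiens) (on this read-out higher numbers stand for an effect only at larger amounts of compound and lower numbers for an effect already at smaller amounts), compound 1 reaches only a limit of the assay, > 1000 nM.
Compound 2 `O=c1[nH]c(=O)n([C@@H]2O[C@H](COP(=O)(O)OP(=O)(O)O)[C@@H](O)[C@H]2O)cc1Br`: in this assay compound 2 gives 3670 nM.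
Compound 3 `Cc1cc(=O)n([C@@H]2O[C@H](COP(=O)(O)OP(=O)(O)O)[C@@H](O)[C@H]2O)c(=O)[nH]1`: in this assay compound 3 reaches only a limit of the assay, > 1000 nM.

The difference between the cores of compound 1 and compound 2 is not broken down here. From compound 1 to compound 3 the change is a hydrogen atom in place of a group of 4 heavy atoms (3 oxygen, 1 phosphorus; no ring), on an oxygen, and in this assay it gives a step that the two limits leave unreadable from compound 1 to compound 3. Compound 4 `O=c1[nH]c(=O)n([C@@H]2O[C@H](COP(=O)(O)O)[C@@H](O)[C@H]2O)cc1Br` has not yet been measured; it differs from compound 2 by a hydrogen atom in place of a group of 4 heavy atoms (3 oxygen, 1 phosphorus; no ring), on an oxygen, the same change made once more. Since compound 2 already sits close to the limit of > 1000 nM in this assay, at which 2 of the 3 values shown sit, any loss would carry compound 4 to that limit. The step from compound 2 to compound 4 is therefore expected to be a 5.4-fold higher number from compound 2 to compound 4 (0.74 log units; beyond the scatter). Compound 4 is expected to give about 20000 nM, somewhere between 4000 nM and 100000 nM, quite possibly reported only as a limit.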

Compound 4, half-maximal effective concentration: > 1000 nM
Compound 4 gave a limit, no number (the forecaster's own chance of this, stated with the estimate: 70%); the middle value is on the limit's open side.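

Compound 4 gives only a limit in this assay, > 1000 nM, so the step from compound 2 to compound 4 cannot be read. The compounds shown leave open where compound 1, compound 3 and compound 4 really lie: the limit of > 1000 nM in this assay, at which 3 of the 4 values shown sit.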